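A few compounds are considered here, and "the series" means these few. Any claim that something is new, unique, unknown or untested is made for them only; others in the source may bear on it.

Measured so far in a functional assay on A549 cells (Homo sapiens) for inhibition, read by MTT assay, with a stated time of 72 h; a lower number here means a stronger inhibitor, a higher number a weaker inhibitor:

Compound 1, `O=C(Nc1ccc(Oc2ccnc3[nH]ccc23)c(F)c1)c1cn(-c2ccccc2)c2ccccc2c1=O`, gives 420 nM in this assay.
Compound 2, `O=C(Nc1ccc(Oc2ccnc3[nH]ccc23)c(F)c1)c1cn(-c2ccc(F)cc2)c2ccccc2c1=O`, gives 290 nM in this assay.
Compound 3, `O=C(Nc1ccc(Oc2ccnc3[nH]ccc23)c(F)c1)c1cn(-c2ccc(Cl)cc2)c2ccccc2c1=O`, gives 320 nM in this assay.

On the numbers shown, compound 3 sits between the other two: the gap to its nearest neighbour is a 1.1-fold higher number from compound 2 to compound 3 (0.04 log units; within the scatter), and the gap to the furthest is a 1.3-fold lower number from compound 1 to compound 3 (0.12 log units; within the scatter). Both gaps sit within the scatter, so the three measured compounds are not separated by this assay.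

Compound 4, `O=C(Nc1ccc(Oc2ccnc3[nH]ccc23)c(F)c1)c1cn(-c2ccc(Br)cc2)c2ccccc2c1=O`, differs from compound 3 by bromo in place of chloro on an aromatic carbon. Among the compounds with values here, the steps that bear on it are the substitutions at the same aromatic carbon: a 1.4-fold lower number from compound 1 to compound 2 (0.16 log units; within the scatter), a 1.3-fold lower number from compound 1 to compound 3 (0.12 log units; within the scatter) and a 1.1-fold higher number from compound 2 to compound 3 (0.04 log units; within the scatter). None of these moves the number beyond the scatter, so a fourth halogen at this position is expected to behave alike, and the step is estimated as a 1.0-fold lower number from compound 3 to compound 4 (0.01 log units; within the scatter), with no direction beyond the scatter.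

Compound 4 is therefore expected to give about 310 nM in this assay, with a range from 150 nM to 650 nM.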

Compound 4, half-maximal inhibitory concentration: 950 nM
Compound 4: middle estimate off by 3.1-fold (0.49 log units), on the low side; measured number outside the range, above it.
By their numbers in this assay, from the lowest: compounds 2, 3 and 1 (each within the scatter of the next); then compound 4.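

In this assay, within the data shown here, bromo is the first group to move the number beyond the scatter at this aromatic carbon, para to a large group (a 3.0-fold higher number from compound 3 to compound 4 (0.47 log units; beyond the scatter); a 3.3-fold higher number from compound 2 to compound 4 (0.52 log units; beyond the scatter); a 2.3-fold higher number from compound 1 to compound 4 (0.35 log units; beyond the scatter)). Hydrogen, fluoro and chloro are not separated here, so the position tolerates some changes, but compound 4 stands apart from all three as the weakest of the four, and the change from 4-chlorophenyl to 4-bromophenyl marks an abrupt break rather than a graded trend across the halogens. No measurement available here accounts for this break.

From the compounds shown here alone, it remains open whether the drop is peculiar to bromo or also appears with iodo, methyl or methoxy at this carbon. Going by these compounds, how an amine or a carboxylic acid would fare at the same place is also open.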